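Opening the Side-Chain Ring of Compound 3

The source may report more compounds than this note shows. Statements on the series, on what has been measured and on what is new or still open speak of the compounds shown alone.

In a functional assay on SK-BR-3 cells (Homo sapiens) for antiproliferative activity (on this read-out lower numbers stand for stronger inhibition and higher numbers for weaker inhibition), compound 1 `CC(=O)Oc1ccc(C(=O)Nc2cc3ccc(OCC4CCN(C)C4)c(C)c3oc2=O)cc1CC=C(C)C` gives 880 nM, compound 2 `CC(=O)Oc1ccc(C(=O)Nc2cc3ccc(OCCC4CCCCN4)c(C)c3oc2=O)cc1CC=C(C)C` gives 640 nM and compound 3 `CC(C)=CCc1cc(C(=O)Nc2cc3ccc(OCC4CCN(C)C4)c(C)c3oc2=O)ccc1O` gives 920 nM. Compound 3 thus stands within the scatter of both other compounds, and the three values form a single group.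

Compound 4 `CCN(C)CCCOc1ccc2cc(NC(=O)c3ccc(O)c(CC=C(C)C)c3)c(=O)oc2c1C` differs from compound 3 in one place: 2-(ethyl(methyl)amino)ethyl in place of 1-methylpyrrolidin-3-yl on a saturated chain carbon bound to an oxygen on an aromatic ring. The closest evidence is a 1.4-fold lower number from compound 1 to compound 2 (0.14 log units; within the scatter), where the same 1-methylpyrrolidin-3-yl, at the same place, gives way to another group. Among the compounds with values here, that entering group keeps a ring, however, so no measured step shows what happens with an entering group that has no ring. Within the data shown here, the other measured step, a 1.0-fold higher number from compound 1 to compound 3 (0.02 log units; within the scatter), concerns the acetyl on the other side of the molecule and says only that compound 3 tracks compound 1.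

With both steps this small, no step beyond the scatter is expected in this assay, though the evidence is thin. The estimated step is a 1.2-fold lower number from compound 3 to compound 4 (0.06 log units; within the scatter). For compound 4 the expected value is 800 nM, with an estimated range from 350 nM to 1800 nM.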

Compound 4, half-maximal inhibitory concentration: 730 nM
Compound 4: the middle estimate sits 1.1-fold (0.04 log units) above what was measured; the range from low to high includes it.
By their numbers in this assay, from the lowest: compounds 2, 4, 1 and 3 (each within the scatter of the next).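

In this assay, within the data shown here, replacing the 1-methylpyrrolidin-3-yl group with the open 2-(ethyl(methyl)amino)ethyl chain, on a saturated chain carbon bound to an oxygen on an aromatic ring, gives a 1.3-fold lower number from compound 3 to compound 4 (0.10 log units; within the scatter) and so no step that can be told from the scatter. Among these compounds, the heavy-atom count stays the same and only the ring goes, so this pair shows for the first time that a side chain with no ring at this place stays in the same group of values as the ring-bearing side chains of compounds 1, 2 and 3. No measurement at hand gives any reason for this result.

Going by these compounds, whether an amide or a carboxylic acid in place of the amine of this chain would hold the value in that group remains open. So does the effect of a shorter or longer chain, or of an acetyl on the phenol oxygen of compound 4.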